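The compounds below may be only part of what the source reports. "The series", "measured", "known", "first", "only" and "open" are said of these compounds alone.

Compound 1 `CC(C)n1nc(-c2ccon2)c2c(N)ncnc21` and compound 2 `CC(C)n1nc(/C=N/OCc2ccccc2)c2c(N)ncnc21` share one core and differ only in the group attached to it. In an assay on BaF3 cells for inhibition of proto-oncogene tyrosine-protein kinase receptor Ret variant V804M (Homo sapiens), read by MTT assay, with a stated time of 48 h (on this read-out lower numbers stand for stronger inhibition of growth and higher numbers for weaker inhibition of growth), compound 1 gives 8940 nM. For compound 2 this assay reports only a limit, > 10000 nM, so compound 2 sits at the limit of > 10000 nM in this assay, at which 1 of the 2 values shown sits, and no exact number is known for it. Compound 3 `CC(C)n1nc(/C=N/O)c2c(N)ncnc21` is compound 2 with hydrogen in place of benzyl on an oxygen. Among the measured compounds shown here, no measured step of this kind is available, so a change within the usual scatter is expected: a number no higher from compound 2 to compound 3 (the limit leaves the size open). Compound 3 is therefore estimated at 10000 nM, in a range from 2500 nM to 40000 nM.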

Compound 3, concentration for 50% growth inhibition: > 10000 nM
Compound 3 ended at the assay's limit (the forecaster's own chance of this, stated with the estimate: 50%); the middle value lies on the limit itself.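

Taking benzyl off the oxygen still gives no exact number in this assay, and the step between these two limits cannot be read: the limit of > 10000 nM in this assay, at which 2 of the 3 values shown sit. Swapping the five-membered aromatic ring on the aromatic carbon of the shared core for the smaller group brings an at least 1.1-fold higher number from compound 1 to compound 3 (0.04 log units; that floor lies within the scatter), so no real change can be claimed for this swap. On these data alone, whether a methyl group or a longer chain on that oxygen would bring a measurable number stays open, as does whether an amine on the aromatic carbon would.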